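The source may report more compounds than this note shows. Statements on the series, on what has been measured and on what is new or still open speak of the compounds shown alone.

Measured so far:
- compound 1, `Brc1cccc(CSc2nnc(-c3ccncc3)n2-c2ccccc2)c1`: 7040 nM
- compound 2, `c1ccc(CSc2nnc(-c3ccncc3)n2-c2ccccc2)cc1`: 12900 nM

Both compounds were tested in a functional assay on HepG2 cells (Homo sapiens) for inhibition, read by MTT assay, with a stated time of 48 h; on this read-out lower numbers stand for stronger inhibition and higher numbers for weaker inhibition. Among the compounds with values here, compound 2 holds the highest of the two numbers, with compound 1 as its only neighbour; the step of a 1.8-fold higher number from compound 1 to compound 2 (0.26 log units; within the scatter) is within the scatter, so the two compounds cannot be told apart with confidence.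

Compound 3, `O=[N+]([O-])c1ccccc1CSc1nnc(-c2ccncc2)n1-c1ccccc1`, has not yet been measured. It differs from compound 2 in one place: nitro in place of hydrogen on an aromatic carbon. The group enters on the same benzyl ring that carries the bromo in compound 1, though not at the same spot.

Within the data shown here, only one measured step speaks to a change on this ring, namely a 1.8-fold higher number from compound 1 to compound 2 (0.26 log units; within the scatter), and it was small. Among the measured compounds shown here, a nitro group has not been tried anywhere in this set, so no measured step tells how this exact change behaves. The expectation is therefore cautious: a modest step in this assay, most likely toward a somewhat lower number, of about a 1.4-fold lower number from compound 2 to compound 3 (0.16 log units; within the scatter). On that basis compound 3 is estimated at 9000 nM, with a plausible range from 3000 nM to 30000 nM.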

Compound 3, half-maximal inhibitory concentration: > 50000 nM
Compound 3 was reported as a limit; the forecaster's own chance of this, stated with the estimate: 10%; at least 5.5-fold (0.74 log units) between middle value and limit.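

In this assay, compound 3 is reported only as a limit, not as a number: the limit of > 50000 nM in this assay, at which 1 of the 3 values shown sits.

Within the data shown here, until now, the only measured change on this ring was a step within the scatter, so the ring could have seemed to tolerate substitution freely. Putting 2-nitrophenyl in place of phenyl gives an at least 3.8-fold higher number from compound 2 to compound 3 (0.58 log units; beyond the scatter), which shows that what this ring carries can matter and that a single added group can clearly weaken inhibition. Comparing the 2-nitrophenyl group with the 3-bromophenyl group gives a similar picture, an at least 7.1-fold higher number from compound 1 to compound 3 (0.85 log units; beyond the scatter), and the true size of both steps remains open-ended.

The compounds shown leave open whether the nitro group itself or its place on the ring, ortho to a large group, sets this step, as the bromo and nitro groups sit at different spots and differ in kind. Also open, on these data alone, is how an amine or a methoxy group on this ring would read in this assay, and whether any group here can give clearly stronger inhibition than the unsubstituted ring.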